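Swapping benzyl for 4-isopropylphenyl in a pyrimidine series

A few compounds are considered here, and "the series" means these few. Any claim that something is new, unique, unknown or untested is made for them only; others in the source may bear on it.

This account concerns three measured compounds and a fourth that awaits measurement in an ADME assay on L02 cells (Homo sapiens) for inhibition, read by CCK-8 assay, with a stated time of 48 h; a higher number here means a weaker inhibitor of growth, a lower number a stronger inhibitor of growth. Compound 1 `Cc1ccccc1Nc1nc(Nc2cc(Cl)ccn2)ncc1Cl` gives 41500 nM in this assay. Compound 2 `Cc1ccccc1Nc1nc(Nc2ccc(N3CCN(C(=O)OC(C)(C)C)CC3)cc2)ncc1Cl` gives 1750 nM, the lowest number of the three. Compound 3 `CN1CCN(c2ccc(Nc3ncc(Cl)c(NCc4ccccc4)n3)nc2)CC1` gives 20300 nM, which places it second highest of the three numbers; compound 1 stands nearest, with a higher number, a gap beyond the scatter, while compound 2 stands furthest, with a lower number, also beyond the scatter.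

Compound 4 `CC(C)c1ccc(Nc2nc(Nc3ccc(N4CCN(C)CC4)cn3)ncc2Cl)cc1` differs from compound 3 in one place: 4-isopropylphenyl in place of benzyl on a nitrogen on an aromatic ring. Among the measured compounds shown here, no step between two measured compounds shows exactly this change, so the direction can only be judged from the spread of the numbers seen so far, where compound 2 sits well below compound 3.

Compound 4 is therefore expected to give a lower number than compound 3 in this assay, a step of a 2.5-fold lower number from compound 3 to compound 4 (0.40 log units; beyond the scatter) that is estimated to be modest but beyond the scatter. The estimate for compound 4 is 8000 nM, with a range from 2000 nM to 30000 nM.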

Compound 4, concentration for 50% growth inhibition: 13700 nM
Beside the measured number, compound 4's estimate is 1.7-fold (0.23 log units) below it; the range from low to high includes it.
By their numbers in this assay, from the lowest: compound 2; then compounds 4 and 3 (each within the scatter of the next); then compound 1.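

Among the compounds shown here, the swap of benzyl for 4-isopropylphenyl on a nitrogen on an aromatic ring gives the first direct reading at this position, since the earlier compounds offered no step between two measured compounds that differ in one place. In this assay that reading is a 1.5-fold lower number from compound 3 to compound 4 (0.17 log units; within the scatter), so the two compounds cannot be told apart, and the expected drop beyond the scatter does not appear. At this place, then, a group of 7 heavy atoms can give way to one of 9, and benzylamino to (4-isopropylphenyl)amino, with no difference this assay can resolve; nothing available here bears on why the number holds.

The change alters two things at once, as the carbon that stands between the ring and the nitrogen in benzyl goes and an isopropyl group arrives, and the compounds shown do not separate these two parts. Going by these compounds, it also remains open how the number would respond at this nitrogen to a plain phenyl, to a longer chain such as phenylethyl, or to a phenyl ring carrying a carboxylic acid or an amine.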